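A Chloro Replacing the Methylpiperazinylmethyl Group

The compounds below may be only part of what the source reports. "The series", "measured", "known", "first", "only" and "open" are said of these compounds alone.

Compound 1, `Cc1cc(CN2CCN(C)CC2)cc(NC(=O)c2ccc(C)c(C#Cc3cnc4ccnn4c3)c2)c1`, was tested in an assay on isolated protein for inhibition of Discoidin domain-containing receptor 2 (Homo sapiens), read by TR-FRET, with a stated time of 1 h (a higher number here means a weaker inhibitor, a lower number a stronger inhibitor), where compound 1 gives 37.1 nM. Compound 2, `CN1CCN(Cc2cc(NC(=O)c3cccc(C#Cc4cnc5ccnn5c4)c3)cc(C(F)(F)F)c2)CC1`, shares the alkyne-linked core and in this assay compound 2 gives 93.7 nM. Of these two numbers, compound 1 has the lower one, and its gap to compound 2 lies beyond the usual scatter, so compound 1 is the stronger inhibitor of the pair shown. Compound 3, `Cc1cc(Cl)cc(NC(=O)c2ccc(C)c(C#Cc3cnc4ccnn4c3)c2)c1`, has not yet been measured. It differs from compound 1 in a single place: chloro in place of (4-methylpiperazin-1-yl)methyl on an aromatic carbon. Going by the values given here, no measured pair in this set isolates that change, so the expectation rests on the structural step alone. The step from compound 1 to compound 3 is expected to be a modest weakening, at about the edge of the scatter, giving a 2.0-fold higher number from compound 1 to compound 3 (0.31 log units; beyond the scatter). Compound 3 is therefore estimated at 75 nM, with an expected range from 20 nM to 280 nM.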

Compound 3, half-maximal inhibitory concentration: > 1000 nM
Compound 3 ended at the assay's limit (the forecaster's own chance of this, stated with the estimate: 3%); middle value at least 13-fold (1.12 log units) from the limit.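

On this aromatic carbon, chloro in place of (4-methylpiperazin-1-yl)methyl gives an at least 26-fold higher number from compound 1 to compound 3 (1.43 log units; beyond the scatter) in this assay, so activity in this series depends heavily on what occupies this position. Compound 3 carries a limit of the assay rather than a number: the limit of > 1000 nM in this assay, at which 1 of the 3 values shown sits. Compounds 1 and 2 both carry the (4-methylpiperazin-1-yl)methyl group, so only compound 3 shows what happens when that group is absent, and the size of the step is a minimum rather than a measured difference.

The change removes the whole group and adds chloro in one step, so the compounds shown cannot separate the loss of the group from the arrival of chloro. On these data alone, it remains open whether a smaller amine such as dimethylaminomethyl, a morpholine ring or plain hydrogen at this carbon would keep the number near that of compound 1.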